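The compounds below may be only part of what the source reports. "The series", "measured", "known", "first", "only" and "open" are said of these compounds alone.

Compound 1 `CN(C)c1ncnc2c1ncn2[C@@H]1O[C@H](CO[Si](C)(C)C(C)(C)C)[C@@]2(OS(=O)(=O)C=C2N)[C@H]1O[Si](C)(C)C(C)(C)C`, in a functional assay on MT4 cells (Homo sapiens) for cytotoxicity (on this read-out lower numbers stand for higher toxicity in this test and higher numbers for lower toxicity in this test), compound 1 gives 15000 nM. Compound 2 `Cn1cnc2ncn([C@@H]3O[C@H](CO[Si](C)(C)C(C)(C)C)[C@@]4(OS(=O)(=O)C=C4N)[C@H]3O[Si](C)(C)C(C)(C)C)c2c1=O`, in this assay compound 2 gives 156000 nM.

For the measured compounds named here, compound 2 stands highest of the two numbers; the one measured step, a 10-fold higher number from compound 1 to compound 2 (1.02 log units; beyond the scatter), was large and beyond the scatter. Compound 3 `CC(C)(C)[Si](C)(C)OC[C@H]1O[C@@H](n2c(=O)[nH]c(=O)c3[nH]cnc32)[C@H](O[Si](C)(C)C(C)(C)C)[C@]12OS(=O)(=O)C=C2N` differs from compound 2 by a group of 11 heavy atoms (5 carbon, 4 nitrogen, 2 oxygen; one five-membered aromatic ring with 2 hetero atoms, one six-membered aromatic ring with 2 hetero atoms) in place of a group of 11 heavy atoms (6 carbon, 4 nitrogen, 1 oxygen; one five-membered aromatic ring with 2 hetero atoms, one six-membered aromatic ring with 2 hetero atoms), on a saturated ring carbon. Going by the values given here, no measured step matches this change, so only the direction from compound 1 to compound 2 offers a hint. A small step is expected, a 1.3-fold higher number from compound 2 to compound 3 (0.11 log units; within the scatter), within or just beyond the scatter. Compound 3 is therefore estimated at 200000 nM, ranging from 80000 nM to 500000 nM.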

Compound 3, half-maximal cytotoxic concentration: 14000 nM
The estimate for compound 3 lay 14-fold (1.15 log units) above the measured number; measured number outside the range, below it.
By their numbers in this assay, from the lowest: compounds 3 and 1 (each within the scatter of the next); then compound 2.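

On this assay the group on this saturated ring carbon moves the number down as well as up: compound 3, whose group has two hydrogen-bond donors, shows an 11-fold lower number from compound 2 to compound 3 (1.05 log units; beyond the scatter) when it replaces the group of compound 2. Set against compound 1, the same group gives a 1.1-fold lower number from compound 1 to compound 3 (0.03 log units; within the scatter) and so leaves compound 2 alone apart from the other two. No measured evidence accounts for either step.

As far as these compounds go, it remains open which feature of the entering group matters. From the compounds shown here alone, it is also open whether a carboxylic acid or a longer chain at this ring carbon would fall nearer compound 2 or nearer compound 1 and compound 3.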